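Compound 4 from compound 1: aryl group exchange

This account rests on a few compounds, and the source may have more. Where it says the series, first, only, none or still open, it means among the compounds named here.

The series is tracked in a physicochemical assay for lipophilicity, read by HPLC, at pH 7.5; on this read-out higher numbers stand for higher lipophilicity and lower numbers for lower lipophilicity. Compound 1 `CC[C@@H](Nc1c(C#N)c(-c2ccc(-c3cccc(C)c3F)cc2)nc2cnccc12)C(N)=O` gives 3 and stands second highest of the three numbers in hand. Compound 2 `CCCCC(Nc1c(C#N)c(-c2ccc(-c3ccccc3OCC)cc2)nc2cnccc12)C(N)=O` gives 3.6, above compound 1 beyond the scatter, while compound 3 `CC[C@@H](Nc1c(C#N)c(-c2ccc(-c3cccc(C)c3F)cc2)nc2cnccc12)C(=O)O` gives 2.1, the lowest of the three. Among the measured compounds shown here, the only step between compounds that differ in a single place is a number 0.90 log units lower from compound 1 to compound 3 (beyond the scatter).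

Compound 4 `CC[C@@H](Nc1c(C#N)c(-c2ccc(-c3ccccc3C(F)(F)F)cc2)nc2cnccc12)C(N)=O` differs from compound 1 as follows: 2-(trifluoromethyl)phenyl in place of 2-fluoro-3-methylphenyl on an aromatic carbon. For the measured compounds named here, no measured step bears directly on this change: the step from compound 1 to compound 3 alters the carbonyl end, not the aryl group, and compound 2 differs from compound 1 in more than one place, so its value shows only where another member of the series sits. Going by the values given here, with no comparable precedent, the expectation rests on the comparison of the two groups alone, which suggests at most a small rise, within the scatter, so the expected step is a number 0.20 log units higher from compound 1 to compound 4 (within the scatter). Compound 4 is therefore estimated at 3.2, with a range from 2.8 to 3.6.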

Compound 4, distribution coefficient: 3.1
Estimate against measurement, compound 4: 0.10 log units above; the range from low to high includes it.
By their numbers in this assay, from the lowest: compound 3; then compounds 1 and 4 (each within the scatter of the next); then compound 2.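

In this assay, among the compounds shown here, the exchange of 2-fluoro-3-methylphenyl for 2-(trifluoromethyl)phenyl, para to a large group, gives a number 0.10 log units higher from compound 1 to compound 4 (within the scatter), the first single-place step at the aryl group. For the compounds shown here, this step stays within the scatter despite 10 heavy atoms entering for 8 and 3 fluorine for 1, whereas the only earlier step, at the carbonyl end, is a number 0.90 log units lower from compound 1 to compound 3 (beyond the scatter). Nothing at hand explains why the two aryl groups read alike.

As far as these compounds go, whether the hydroxy in place of amino step keeps its size with 2-(trifluoromethyl)phenyl in place remains open. So does the reading at this position for an aryl group carrying an amine or a morpholine, since both aryl groups compared here hold only carbon and fluorine.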